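This account rests on a few compounds, and the source may have more. Where it says the series, first, only, none or still open, it means among the compounds named here.

In a physicochemical assay for solubility, in phosphate buffer, with a stated time of 24 h, at pH 7.4, tested at 100 uM (on this read-out lower numbers stand for lower solubility and higher numbers for higher solubility), compound 1 (`O=C(NCc1ccc(S(=O)(=O)c2cncc(C(F)(F)F)c2)cc1)N1Cc2ccncc2C1`) gives 83000 nM, compound 2 (`CC(C)n1cc(S(=O)(=O)c2ccc(CNC(=O)N3Cc4ccncc4C3)cc2)cn1`) gives 192000 nM and compound 3 (`CN1CCN(S(=O)(=O)c2ccc(CNC(=O)N3Cc4ccncc4C3)cc2)CC1`) gives 160000 nM. Compound 3 stands within the scatter of the other two, as shown by a 1.2-fold lower number from compound 2 to compound 3 (0.08 log units; within the scatter) and by a 1.9-fold higher number from compound 1 to compound 3 (0.29 log units; within the scatter). Compound 4 (`O=C(NCc1ccc(S(=O)(=O)N2CC3(CCOCC3)C2)cc1)N1Cc2ccncc2C1`) differs from it by a group of 9 heavy atoms (7 carbon, 1 nitrogen, 1 oxygen; one four-membered non-aromatic ring with 1 hetero atom, one six-membered non-aromatic ring with 1 hetero atom) in place of a group of 7 heavy atoms (5 carbon, 2 nitrogen; one six-membered non-aromatic ring with 2 hetero atoms), on a sulfonyl sulfur. All three measured steps bear on this change, since each swaps the group on the same sulfonyl sulfur. The only one beyond the scatter, a 2.3-fold higher number from compound 1 to compound 2 (0.36 log units; beyond the scatter), is modest, so no step beyond the scatter is expected in this assay. The expected step is a 1.2-fold lower number from compound 3 to compound 4 (0.09 log units; within the scatter). For compound 4 the estimate is 130000 nM, with an expected range of 65000 nM to 220000 nM.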

Compound 4, solubility: 272000 nM
The estimate for compound 4 lay 2.1-fold (0.32 log units) below the measured number; the measured number lies above the stated range.
By their numbers in this assay, from the lowest: compounds 1, 3, 2 and 4 (each within the scatter of the next, the first and the last beyond it).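

In this assay, the group of compound 4, with its four-membered and six-membered non-aromatic rings, keeps this sulfonyl sulfur position within the scatter of 4-methylpiperazin-1-yl and 1-isopropyl-1H-pyrazol-4-yl: a 1.7-fold higher number from compound 3 to compound 4 (0.23 log units; within the scatter) and a 1.4-fold higher number from compound 2 to compound 4 (0.15 log units; within the scatter). Only 5-(trifluoromethyl)pyridin-3-yl stands apart from it, with a 3.3-fold higher number from compound 1 to compound 4 (0.52 log units; beyond the scatter). No supporting data on hand account for these numbers. Open, from the compounds shown here alone, is whether a carboxylic acid or a primary amine on this sulfonyl sulfur would move the number beyond the scatter of compound 4.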